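This account rests on a few compounds, and the source may have more. Where it says the series, first, only, none or still open, it means among the compounds named here.

Measured so far in a functional assay (Homo sapiens) for inhibition of Nucleic Acid, tested at 100 uM; on this read-out lower numbers stand for less inhibition and higher numbers for more inhibition at the one concentration tested (going by the name of the read-out):
compound 1 `CCNc1nccc2c1ncn2C1O[C@H](CO)[C@@H](O)[C@H]1O` — 4%
compound 2 `CN(C)c1nccc2c1ncn2[C@H]1C[C@H](O)[C@@H](CO)O1` — 0%
compound 3 `CC1OC(n2cnc3c(N)nccc32)CC1O` — 3%

Compound 1 carries the highest number of the three, but the gap to compound 3 and the gap to compound 2 both lie within the scatter, so no ranking among the three can be drawn; all three sit near the floor of this assay.

Compound 4 `[N-]=[N+]=Nc1nccc2c1ncn2C1O[C@H](CO)[C@@H](O)[C@H]1O` differs from compound 1 by azido in place of ethylamino on an aromatic carbon. Among the compounds with values here, no pair of measured compounds shows this change, so no measured step can guide it. With every measured compound near zero, the step from compound 1 to compound 4 is expected to fall within the scatter: a number 1 percentage points higher from compound 1 to compound 4 (within the scatter). Compound 4 is therefore estimated at 5%, between -5% and 15%, pending the measurement.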

Compound 4, a percentage reported as inhibition, at one concentration (the size of the read-out at that concentration, not a potency): 4%
Compound 4: the middle estimate sits 1 percentage points above what was measured, and the stated range covers the measured number.
By their numbers in this assay, from the lowest: compounds 2, 3, 1 and 4 (each within the scatter of the next).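

Exchanging the ethylamino group for azido on this aromatic carbon, next to the ring nitrogen, gives no change at the digits printed from compound 1 to compound 4 (within the scatter) in this assay. Within the data shown here, this is the first direct comparison at this position: groups of the same heavy-atom count, one with a hydrogen-bond donor and one without, give no difference on the core of compound 1. No independent evidence bears on this result.

Still open, on these data alone, is whether a longer chain such as hexylamino or a carboxylic acid at this position would lift the read-out clear of the scatter. The compounds shown also leave open whether any group here gives substantial inhibition.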